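Aryl swap on the triazole-methyl arm of the chromone series

The compounds below may be only part of what the source reports. "The series", "measured", "known", "first", "only" and "open" are said of these compounds alone.

Measured so far:
compound 1, `O=c1ccoc2cc(OCc3cn(Cc4ccc(F)cc4)nn3)ccc12`, a functional assay on HeLa cells (Homo sapiens) for cytotoxicity, read by MTT assay, with a stated time of 48 h (a higher number here means a weaker inhibitor, a lower number a stronger inhibitor), 12000 nM
compound 2, `O=c1ccoc2cc(OCc3cn(Cc4cccc([N+](=O)[O-])c4)nn3)ccc12`, this assay 17300 nM

Compound 2 and compound 1 sit within the scatter of each other: the step of a 1.4-fold higher number from compound 1 to compound 2 (0.16 log units; within the scatter) is the only one measured, and it does not separate the two.

Compound 3, `COc1ccc(Cn2cc(COc3ccc4c(=O)ccoc4c3)nn2)cc1`, is the next member. It differs from compound 2 by 4-methoxyphenyl in place of 3-nitrophenyl on a saturated chain carbon bound to an aromatic nitrogen. Going by the values given here, the one step that bears on it, a 1.4-fold higher number from compound 1 to compound 2 (0.16 log units; within the scatter), is also an exchange of the aryl group on the saturated chain carbon bound to the aromatic nitrogen, and it stayed within the scatter. Nothing here shows that a change at this position moves the number beyond the scatter, so no step beyond the scatter is expected in this assay; the estimated step is a 1.2-fold lower number from compound 2 to compound 3 (0.09 log units; within the scatter). Compound 3 is therefore estimated at 14000 nM, with a range from 6000 nM to 35000 nM.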

Compound 3, half-maximal inhibitory concentration: 14400 nM
Compound 3: the middle estimate sits 1.0-fold (0.01 log units) below what was measured, and the stated range covers the measured number.
By their numbers in this assay, from the lowest: compounds 1, 3 and 2 (each within the scatter of the next).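

In this assay, a third aryl group on the saturated chain carbon bound to an aromatic nitrogen again stays within the scatter, with a 1.2-fold lower number from compound 2 to compound 3 (0.08 log units; within the scatter) for 4-methoxyphenyl in place of 3-nitrophenyl. The other new step, a 1.2-fold higher number from compound 1 to compound 3 (0.08 log units; within the scatter), is an exchange of methoxy in place of fluoro on an aromatic carbon, and it does not separate the two compounds either. No measurement is available that would explain these results.

From the compounds shown here alone, whether any group at this position can move the number beyond the scatter remains open, as does the effect of an amine or a carboxylic acid on the aryl ring, or of a longer chain in place of the single saturated chain carbon. Going by these compounds, the shared core is the same in compound 1, compound 2 and compound 3, so the effect of changing it also remains open.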